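This account rests on a few compounds, and the source may have more. Where it says the series, first, only, none or still open, it means among the compounds named here.

Within the data shown here, in a functional assay on HepG2 cells (Homo sapiens) for antiproliferative activity, read by MTT assay, with a stated time of 48 h (on this read-out lower numbers stand for stronger inhibition of growth and higher numbers for weaker inhibition of growth), compound 2 (`Cc1ccc(OCCCN(Cc2ccc(C(=O)NO)cc2)c2ncc(-c3ccc(C)cc3)s2)cc1`) gives 12200 nM, the highest of the three numbers so far. Compound 3 (`CCCCN(Cc1ccc(C(=O)NO)cc1)c1ncc(-c2ccc(C)cc2)s1`) gives 4300 nM, and compound 1 (`CCN(Cc1ccc(C(=O)NO)cc1)c1ncc(-c2ccc(C)cc2)s1`) gives 1120 nM.

The step in question leads to compound 4 (`CCCN(Cc1ccc(C(=O)NO)cc1)c1ncc(-c2ccc(C)cc2)s1`): hydrogen in place of 4-methylphenoxy on a saturated chain carbon, three bonds along the chain from a nitrogen on an aromatic ring. This places hydrogen where 4-methylphenoxy stood, on a saturated chain carbon, three bonds along the chain from a nitrogen on an aromatic ring, so that 3-(4-methylphenoxy)propyl becomes propyl.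

All three measured steps bear on this change. The closest is a 2.8-fold lower number from compound 2 to compound 3 (0.45 log units; beyond the scatter), a modest step at the same place that also removes the 4-methylphenoxy. The large step of an 11-fold higher number from compound 1 to compound 2 (1.04 log units; beyond the scatter) shows how much ground compound 2 has lost relative to the ethyl chain of compound 1. The modest step of a 3.8-fold higher number from compound 1 to compound 3 (0.58 log units; beyond the scatter) spans the ethyl and butyl chains, and propyl is a chain length within that span.

Among the measured compounds shown here, a step toward a lower number is therefore expected, somewhat larger than the one to compound 3 but smaller than the full distance to compound 1. The expected step is a 5.5-fold lower number from compound 2 to compound 4 (0.74 log units; beyond the scatter). The estimate for compound 4 is 2200 nM, with an expected range of 1100 nM to 4500 nM.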

Compound 4, concentration for 50% growth inhibition: 2550 nM
Compound 4: middle estimate off by 1.2-fold (0.06 log units), on the low side; low and high end bracket the measured number.
By their numbers in this assay, from the lowest: compound 1; then compounds 4 and 3 (each within the scatter of the next); then compound 2.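

In this assay, among these compounds, compound 4 isolates the 4-methylphenoxy on an otherwise unchanged propyl chain, and removing that group alone gives a 4.8-fold lower number from compound 2 to compound 4 (0.68 log units; beyond the scatter) in this series, a change the earlier compounds could show only together with a change in chain length. Among the plain chains, a 1.7-fold lower number from compound 3 to compound 4 (0.23 log units; within the scatter) does not separate propyl from butyl, whereas a 2.3-fold higher number from compound 1 to compound 4 (0.36 log units; beyond the scatter) does separate propyl from ethyl, so the only clear difference between neighbouring chain lengths here lies between ethyl and propyl. Nothing available explains any of these steps.

From the compounds shown here alone, it remains open whether the number would keep rising with a longer chain such as pentyl or hexyl, and whether a methyl group or a hydrogen on the same nitrogen would continue the trend seen from compound 4 to compound 1. Going by these compounds, it is also open whether a smaller or different group at the end of the propyl chain, such as an unsubstituted phenoxy, an amine or a carboxylic acid, would give a number nearer that of compound 2 or that of compound 4.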